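The source may report more compounds than this note shows. Statements on the series, on what has been measured and on what is new or still open speak of the compounds shown alone.

Compound 2 `Cc1c(Nc2nc(N)c3c(C#N)c(N4CCC[C@H]4C)n(C)c3n2)cnn1C1COC1` gives 47 nM in an assay on isolated protein for inhibition of Leucine-rich repeat serine/threonine-protein kinase 2 (Homo sapiens), read by TR-FRET and LanthaScreen, with stated times of 50 min and 30 min, in the presence of a further agent that is not named here (a lower number here means a stronger inhibitor, a higher number a weaker inhibitor), and so has the highest number of the two compounds measured; the nearest is compound 1 `C[C@@H]1CCCN1c1c(C#N)c2c(N)nc(Nc3cn[nH]c3)nc2n1C`, which gives 6 nM, a gap that lies beyond the usual scatter.

Compound 3 `C[C@@H]1CCCN1c1c(C#N)c2c(N)nc(Nc3cnn(C)c3)nc2n1C` has not yet been measured in this assay. It differs from compound 2 in one place: 1-methyl-1H-pyrazol-4-yl in place of 5-methyl-1-(oxetan-3-yl)-1H-pyrazol-4-yl on a nitrogen on an aromatic ring. The change therefore strips the oxetane ring and the ring methyl away and leaves a single methyl on the pyrazole nitrogen.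

Among the measured compounds shown here, one measured step bears on this. The step of a 7.8-fold higher number from compound 1 to compound 2 (0.89 log units; beyond the scatter) shows that attaching the methyl and the oxetane to the plain pyrazole raised the number by a modest amount. Compound 3 undoes most of that addition and keeps only a methyl, so it sits closer to compound 1 than to compound 2 in build, and a drop in the number is expected, though not the whole way back, since the methyl stays.

For compound 3 the estimate in this assay is 10 nM, with a range from 4 nM to 30 nM, which means an expected step of a 4.7-fold lower number from compound 2 to compound 3 (0.67 log units; beyond the scatter).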

Compound 3, half-maximal inhibitory concentration: 6 nM
Compound 3: the middle estimate sits 1.7-fold (0.22 log units) above what was measured, and the stated range covers the measured number.
By their numbers in this assay, from the lowest: compounds 1 and 3 (each within the scatter of the next); then compound 2.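

Among the compounds shown here, the earlier pair showed only that adding the ring methyl and the oxetane together raised the number, whereas compound 3 tests the smallest part of that addition alone: in this assay, the step for a methyl in place of hydrogen on the aromatic nitrogen is no change at the digits printed from compound 1 to compound 3 (within the scatter), so this nitrogen of the pyrazole can carry a methyl with no measurable cost. Removing the oxetane and the ring methyl while keeping the methyl on nitrogen gives a 7.8-fold lower number from compound 2 to compound 3 (0.89 log units; beyond the scatter), which places the higher number of compound 2 in what it carries beyond that single methyl: the ring methyl, the oxetane, or the two together. Nothing available here accounts for these numbers in terms of how the groups act.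

The compounds shown do not separate the ring methyl from the oxetane, which would take a pyrazole carrying only one of the two. They also leave open how the assay responds to other groups on this nitrogen, such as an ethyl group, a longer chain ending in an amine, or a carboxylic acid.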